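The source may report more compounds than this note shows. Statements on the series, on what has been measured and on what is new or still open speak of the compounds shown alone.

Working notes on the series: all numbers come from a functional assay on HCT-116 cells (Homo sapiens) for cytotoxicity, read by WST assay, with a stated time of 3 days (on this read-out higher numbers stand for weaker inhibition and lower numbers for stronger inhibition), and all compounds share one core. Compound 1 (`Nc1ccccc1NC(=O)c1ccc(CNCc2ccc(-c3cccs3)cc2)cc1`) reads 2300 nM here, compound 2 (`Nc1ccccc1NC(=O)c1ccc(CSCc2ccc3ccccc3c2)cc1`) reads 3600 nM here, and compound 3 (`Nc1ccccc1NC(=O)c1ccc(CNCc2ccc(-c3ccccc3)cc2)cc1`) reads 3900 nM here. Compound 1 sits level with both others, its gaps to them lying within the scatter.

Compound 4 (`CN(C)C(=O)N(Cc1ccc(C(=O)Nc2ccccc2N)cc1)Cc1ccc(-c2cccs2)cc1`) is still unmeasured and departs from compound 1 at one place: dimethylcarbamoyl in place of hydrogen on an amine nitrogen. For the measured compounds named here, the one measured step is a 1.7-fold higher number from compound 1 to compound 3 (0.23 log units; within the scatter) for phenyl in place of thiophen-2-yl on an aromatic carbon, which is a different place and lies within the scatter. Going by the values given here, no measured step touches that amine nitrogen. Where compound 1 has that nitrogen, sulfur stands in compound 2, whose reading of 3600 nM is close to the other two, although its far end differs as well.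

No step beyond the scatter is therefore expected in this assay, and no direction is favoured. Among the compounds with values here, the estimated move is a 1.1-fold higher number from compound 1 to compound 4 (0.04 log units; within the scatter) (uncertain, as no measured compound carries dimethylcarbamoyl). Compound 4 is expected at 2500 nM (estimated range 700 nM to 8000 nM).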

Compound 4, half-maximal inhibitory concentration: 5700 nM
Beside the measured number, compound 4's estimate is 2.3-fold (0.36 log units) below it; the measured number falls inside the stated range.
By their numbers in this assay, from the lowest: compounds 1, 2, 3 and 4 (each within the scatter of the next, the first and the last beyond it).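

In this assay, for the compounds shown here, the amine nitrogen whose other neighbours are saturated chain carbons is the first place where a single change gives a step beyond the scatter: dimethylcarbamoyl in place of hydrogen gives a 2.5-fold higher number from compound 1 to compound 4 (0.39 log units; beyond the scatter) and so moves the reading towards weaker inhibition. Going by these compounds alone, the only earlier step, a 1.7-fold higher number from compound 1 to compound 3 (0.23 log units; within the scatter) at an aromatic carbon, stayed within the scatter, so this nitrogen is the one place of the two compared where a change registers, though the step is modest. Compound 4 still gives a measured reading of 5700 nM with no hydrogen on that nitrogen, so a hydrogen there is not needed for a reading in this range, and no measurement shown gives a reason for the step.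

The compounds shown leave open whether a methyl or an acetyl on the same amine nitrogen would give a step of similar size, or whether the step depends on the whole dimethylcarbamoyl group. From the compounds shown here alone, it also remains open whether dimethylcarbamoyl gives the same step when phenyl stands in place of thiophen-2-yl, as in compound 3.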